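Ester Variation in the Dihydropyridine Series: Compound 3

A few compounds are considered here, and "the series" means these few. Any claim that something is new, unique, unknown or untested is made for them only; others in the source may bear on it.

Measured so far:
compound 1, `CCOC(=O)C1=C(C)NC(C)=C(C(=O)OC(C)C)C1c1csc(-c2ccc(Cl)cc2)n1` — 2550 nM
compound 2, `CCOC(=O)C1=C(C)NC(C)=C(C(=O)OC2CCCC2)C1c1csc(-c2ccc(Cl)cc2)n1` — 8380 nM

Both compounds were tested in an assay on isolated protein for antagonist activity at Voltage-dependent L-type calcium channel subunit alpha-1C (Cavia porcellus), with a stated time of 15 min; a lower number here means a stronger inhibitor, a higher number a weaker inhibitor. Compound 2 carries the highest of the two numbers; its nearest neighbour is compound 1, which differs by a 3.3-fold higher number from compound 1 to compound 2 (0.52 log units; beyond the scatter), a change of cyclopentyl in place of isopropyl on an oxygen next to a carbonyl group.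

Compound 3, `CCOC(=O)C1=C(C)NC(C)=C(C(=O)OC(C)c2ccccc2)C1c1csc(-c2ccc(Cl)cc2)n1`, has not yet been measured in this assay. Relative to compound 2 the change is 1-phenylethyl in place of cyclopentyl on an oxygen next to a carbonyl group. Among the compounds with values here, the only step on record that touches this ester position is the one from compound 1 to compound 2, and it was modest but beyond the scatter, pointing toward weaker inhibition as the group on that oxygen grew from isopropyl to cyclopentyl. Within the data shown here, the present change enlarges the group again, with 1-phenylethyl in place of cyclopentyl; no measured pair shows what an aromatic group there does. Among the measured compounds shown here, on the single step available, compound 3 is expected to land near compound 2 or somewhat weaker, with a 1.2-fold higher number from compound 2 to compound 3 (0.08 log units; within the scatter) as the estimated step. Compound 3 is therefore estimated at 10000 nM, in the range 3000 nM to 35000 nM.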

Compound 3, half-maximal inhibitory concentration: 13800 nM
Beside the measured number, compound 3's estimate is 1.4-fold (0.14 log units) below it, and the stated range covers the measured number.
By their numbers in this assay, from the lowest: compound 1; then compounds 2 and 3 (each within the scatter of the next).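

In this assay, 1-phenylethyl in place of cyclopentyl on an oxygen next to a carbonyl group gives a 1.6-fold higher number from compound 2 to compound 3 (0.22 log units; within the scatter) and so brings in an aromatic ring at this position with no separation between compound 2 and compound 3. Phenyl in place of methyl on the saturated chain carbon of the isopropyl group gives a 5.4-fold higher number from compound 1 to compound 3 (0.73 log units; beyond the scatter) and so adds a second step beyond the scatter, in the same direction as a 3.3-fold higher number from compound 1 to compound 2 (0.52 log units; beyond the scatter) and with neither of these compounds going against it: among the three, cyclopentyl and 1-phenylethyl both stand as weaker inhibitors than isopropyl, while the aromatic and non-aromatic rings remain indistinguishable. No evidence in hand bears on the reason for these steps.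

Still open, from the compounds shown here alone, is whether a smaller group on this oxygen, such as methyl or ethyl, would give a stronger inhibitor than compound 1 does at 2550 nM in this assay. Also open, going by these compounds, is how a chain ending in an amine or a carboxylic acid would read there, and whether benzyl would behave like 1-phenylethyl.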